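The compounds below may be only part of what the source reports. "The series", "measured", "known", "first", "only" and "open" are said of these compounds alone.

Compound 3 `Cc1cccc(NN2C(S)=NC(C)C2C)c1` gives 360000 nM in a functional assay on MT4 cells (Homo sapiens) for cytotoxicity (a higher number here means that more compound is tolerated, a lower number that less compound is tolerated), the highest of the three numbers recorded here. Compound 1 `CC1N=C(S)N(Nc2cccc(Cl)c2)C1C` gives 259000 nM, and the step of a 1.4-fold higher number from compound 1 to compound 3 (0.14 log units; within the scatter) is within the scatter. Compound 2 `Cc1nc(S)n(Nc2cccc(Cl)c2)c1-c1ccccc1` gives 66700 nM, a number apart from that of compound 3 beyond the scatter. Compound 4 `Cc1cccc(NN2C=NC(C)C2C)c1` differs from compound 3 by hydrogen in place of sulfanyl on a carbon with a double bond to nitrogen, a change on the five-membered non-aromatic ring with 2 nitrogen. For the measured compounds named here, the single measured step, a 1.4-fold higher number from compound 1 to compound 3 (0.14 log units; within the scatter), concerns a group on the aromatic carbon and does not bear on this change; nothing recorded tests loss of the sulfanyl group. No step beyond the scatter is therefore expected, with no change at the digits printed from compound 3 to compound 4 (within the scatter) as the estimated change in this assay. Compound 4 is expected to give about 360000 nM, in the range 120000 nM to 1000000 nM.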

Compound 4, half-maximal cytotoxic concentration: 312000 nM
The estimate for compound 4 lay 1.2-fold (0.06 log units) above the measured number; the measured number falls inside the stated range.
By their numbers in this assay, from the lowest: compound 2; then compounds 1, 4 and 3 (each within the scatter of the next).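

In this assay, hydrogen in place of sulfanyl on the carbon with a double bond to nitrogen gives a 1.2-fold lower number from compound 3 to compound 4 (0.06 log units; within the scatter), so this exchange leaves the number within the scatter. For the compounds shown here, the earlier step concerned only a group on an aromatic carbon; this is the first reading at the ring carbon between two ring nitrogen atoms. No measurement at hand accounts for this result.

On these data alone, whether an amine or a carboxylic acid at this carbon would also stay within the scatter remains open. Also open, as far as these compounds go, is whether the same exchange behaves alike on the core of compound 2.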